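The source may report more compounds than this note shows. Statements on the series, on what has been measured and on what is new or still open speak of the compounds shown alone.

In an assay on HEK293 cells for agonist activity at Toll-like receptor 8 (Homo sapiens), read by spectrophotometry (on this read-out lower numbers stand for an effect already at smaller amounts and higher numbers for an effect only at larger amounts of compound), compound 3 `CCCCNc1nc(N)nc(C)c1CCCC` gives 780 nM. Compound 2 `CCCCNc1nc(N)nc(C)c1CCCn1ccc2ccccc21` gives 1100 nM, which lies within the scatter of compound 3, so the two cannot be told apart. Compound 1 `CCCCNc1nc(N)nc(C)c1C#CCN1CCCCC1` gives 3790 nM, and its gap to compound 3 lies beyond the scatter. Compound 3 thus sits at the low end of the three numbers, sharing that end with compound 2. Compound 4 `CCCCNc1nc(N)nc(C)c1CCCN1CCCC1` is not yet measured; it differs from compound 3 by pyrrolidin-1-yl in place of methyl on a saturated chain carbon, three bonds along the chain from an aromatic carbon. For the measured compounds named here, no measured pair shows this change. A step upward in this assay is expected, a 2.1-fold higher number from compound 3 to compound 4 (0.31 log units; beyond the scatter), mainly because compound 1 gives 3790 nM against the number of compound 3. Compound 4 is accordingly estimated at 1600 nM, within 500 nM to 5000 nM.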

Compound 4, half-maximal effective concentration: 110 nM
Beside the measured number, compound 4's estimate is 15-fold (1.16 log units) above it, outside the stated range (below it).
By their numbers in this assay, from the lowest: compound 4; then compounds 3 and 2 (each within the scatter of the next); then compound 1.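

Working from this assay, the saturated chain end proves responsive to the group it carries: pyrrolidin-1-yl in place of methyl, three bonds along the chain from an aromatic carbon, gives a 7.1-fold lower number from compound 3 to compound 4 (0.85 log units; beyond the scatter). For the compounds shown here, this is the first readable single-place step, and it lies beyond the scatter. No available evidence bears on the origin of this step.

Still open, on these data alone, is whether the ring or its nitrogen accounts for the step; a diethylamino group or a cyclopentyl group at the same place would separate the two. A longer chain carrying the pyrrolidin-1-yl would test how far the group can sit from the shared core.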